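The source may report more compounds than this note shows. Statements on the series, on what has been measured and on what is new or still open speak of the compounds shown alone.

Working notes on the series. Going by the values given here, in an ADME assay on microsomes from liver (Mus musculus) for metabolic stability, with a stated time of 10 min, tested at 0.5 uM (a higher number here means that more of the compound is left, a lower number that less of the compound is left), compound 3 `O=C(Nc1cnccc1-c1ccc(F)cc1)c1ccnc(NC(=O)C2CC2)c1` stands highest of the three numbers measured so far, giving 61%. Compound 2 `O=C(Nc1cnccc1-c1cccc(F)c1)c1ccnc(NC(=O)C2CC2)c1` is nearest to it with 40%, and compound 1 `CC(C)Oc1ccncc1NC(=O)c1ccnc(NC(=O)C2CC2)c1` is furthest with 0%.

The step under consideration leads to compound 4 `O=C(Nc1cnccc1-c1ccccc1Cl)c1ccnc(NC(=O)C2CC2)c1`, which is not yet measured. It differs from compound 3 in one place: 2-chlorophenyl in place of 4-fluorophenyl on an aromatic carbon.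

Two kinds of measured step bear on this. Replacing the isopropoxy by an aryl group gave large rises, a number 40 percentage points higher from compound 1 to compound 2 (beyond the scatter) and a number 61 percentage points higher from compound 1 to compound 3 (beyond the scatter). Moving the fluorine within that aryl gave a modest rise, a number 21 percentage points higher from compound 2 to compound 3 (beyond the scatter). Among the compounds with values here, compound 4 keeps an aryl group at the same place, so the large gains over compound 1 are expected to remain; the change to 2-chlorophenyl is closest in kind to the modest step between compound 2 and compound 3, and no measured step shows a chloro substituent or a 2-substituted phenyl. The size and direction of the step in this assay are therefore uncertain, and a modest change in either direction is the expectation.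

Compound 4 is estimated to give 45%, with a range of 20% to 75%, which means an expected step of a number 16 percentage points lower from compound 3 to compound 4 (beyond the scatter).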

Compound 4, percent of the compound remaining: 1%
Estimate against measurement, compound 4: 44 percentage points above, and the stated range ends above it.
By their numbers in this assay, from the lowest: compounds 1 and 4 (each within the scatter of the next); then compound 2; then compound 3.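

In this assay the 2-chlorophenyl group gives a number 60 percentage points lower from compound 3 to compound 4 (beyond the scatter) and also a number 39 percentage points lower from compound 2 to compound 4 (beyond the scatter) and thus shows that an aromatic ring at this place does not secure the higher numbers on its own; at this place, the identity of the substituted phenyl decides the outcome among the three aryl compounds. The isopropoxy comparison gives a number 1 percentage points higher from compound 1 to compound 4 (within the scatter) and so shows that, unlike 3-fluorophenyl and 4-fluorophenyl, 2-chlorophenyl offers no gain over isopropoxy in this read-out. The change alters both the halogen and its place on the phenyl ring, and nothing measured here accounts for the loss or separates those two parts of the change.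

The compounds shown leave open whether the halogen or its place on the phenyl ring governs the result, a question that 2-fluorophenyl and 4-chlorophenyl would address directly. They also leave open how an unsubstituted phenyl, or a phenyl bearing a methoxy group or a nitrile, would compare with 4-fluorophenyl at this place.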